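Bromo for chloro on the arylsulfonyl group

The source may report more compounds than this note shows. Statements on the series, on what has been measured and on what is new or still open speak of the compounds shown alone.

- compound 1 `Cc1ccc(S(=O)(=O)N2C/C(=C\c3cccnc3)C(=O)/C(=C/c3ccccc3F)C2)cc1`: 9700 nM
- compound 2 `O=C1/C(=C/c2cccnc2)CN(S(=O)(=O)c2ccc(Cl)cc2)C/C1=C\c1ccccc1F`: 12100 nM

In a functional assay on QGY-7703 cells (Homo sapiens) for cytotoxicity, read by MTT assay, with a stated time of 24 h (a lower number here means a stronger inhibitor, a higher number a weaker inhibitor), compound 2 gives 12100 nM, level with compound 1 within the scatter. The next compound, compound 3 `O=C1/C(=C/c2cccnc2)CN(S(=O)(=O)c2ccc(Br)cc2)C/C1=C\c1ccccc1F`, differs from compound 2 as follows: bromo in place of chloro on an aromatic carbon. This is bromo in place of chloro on an aromatic carbon, turning 4-chlorophenyl into 4-bromophenyl. Among the measured compounds shown here, only one measured step bears on this change: chloro in place of methyl on the same aromatic carbon, a 1.2-fold higher number from compound 1 to compound 2 (0.10 log units; within the scatter), which stays within the scatter. For the measured compounds named here, no bromo compound has been measured, and a single step is thin evidence. A step beyond the scatter is therefore not expected in this assay, and no direction can be given. The expected step is a 1.1-fold lower number from compound 2 to compound 3 (0.02 log units; within the scatter). Compound 3 is estimated at 11500 nM, with an expected range of 6500 nM to 20000 nM.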

Compound 3, half-maximal inhibitory concentration: 12800 nM
For compound 3 the middle estimate is 1.1-fold (0.05 log units) below the measured one; low and high end bracket the measured number.
By their numbers in this assay, from the lowest: compounds 1, 2 and 3 (each within the scatter of the next).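

In this assay, the change from chloro to bromo on this aromatic carbon stays within the scatter (a 1.1-fold higher number from compound 2 to compound 3 (0.02 log units; within the scatter)). The wider change from the methyl of compound 1 to bromo also stays within the scatter (a 1.3-fold higher number from compound 1 to compound 3 (0.12 log units; within the scatter)), so methyl, chloro and bromo at this place, para to a large group, cannot be told apart in this series. No measurement at hand explains this flat reading.

From the compounds shown here alone, whether a different kind of group at this place, such as an amine, a carboxylic acid or a methoxy group, would give a step beyond the scatter remains open. Also open, going by these compounds, is whether these three groups would still read alike if the pyridine or fluorophenyl parts of the shared core were changed.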